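The compounds below may be only part of what the source reports. "The series", "measured", "known", "first", "only" and "open" are said of these compounds alone.

Measured compounds in a functional assay on HepG2 cells (Homo sapiens) for antiproliferative activity, read by MTT assay, with a stated time of 48 h; on this read-out higher numbers stand for weaker inhibition and lower numbers for stronger inhibition:
Compound 1 `N#CC1=C(N)Oc2c(c3nc4ccccc4nc3c3ccccc23)C12C(=O)N(Cc1cnnn1-c1cccc(Br)c1)c1ccccc12` gives > 50000 nM, a limit of the assay and not a number.
Compound 2 `COc1ccccc1-n1nncc1CN1C(=O)C2(C(C#N)=C(N)Oc3c2c2nc4ccccc4nc2c2ccccc32)c2ccccc21` gives > 50000 nM, again a limit of the assay.
Compound 3 `N#CC1=C(N)Oc2c(c3nc4ccccc4nc3c3ccccc23)C12C(=O)N(Cc1cnnn1-c1ccc(N)cc1)c1ccccc12` gives > 50000 nM, again a limit of the assay.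

Compound 1 therefore stands at the limit of this assay, and the three measured values carry no number that would set it apart from compound 2 or compound 3. The three measured steps, a step that the two limits leave unreadable from compound 1 to compound 2, a step that the two limits leave unreadable from compound 1 to compound 3 and a step that the two limits leave unreadable from compound 2 to compound 3, are all of unreadable size, since each end of each step is a limit. Among the compounds with values here, the only evidence the measured set offers is the limit of > 50000 nM in this assay, at which 3 of the 3 values shown sit, which shows that exchanging one aryl group for another on the aromatic nitrogen has not, in any of the three cases, brought a compound inside the measurable range.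

The step from compound 1 to compound 4 `N#CC1=C(N)Oc2c(c3nc4ccccc4nc3c3ccccc23)C12C(=O)N(Cc1cnnn1-c1ccc(F)c(Cl)c1)c1ccccc12` is a change of the same kind: 3-chloro-4-fluorophenyl in place of 3-bromophenyl on an aromatic nitrogen. Within the data shown here, all three measured steps bear on it, and none of them could be read; no step in this assay is expected beyond a continued limit. Compound 4 is expected to give 80000 nM, with a range of 20000 nM to 400000 nM, and the expected step from compound 1 is a step that the limit leaves unreadable from compound 1 to compound 4.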

Compound 4, half-maximal inhibitory concentration: > 50000 nM
Compound 4: a limit, no number; the forecaster's own chance of this, stated with the estimate: 85%; the middle value does not contradict the limit.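

Compound 4 gives > 50000 nM in this assay, again a limit of the assay and not a number. Its steps to compound 1, compound 2 and compound 3 therefore cannot be read, and the set rests on one observation: the limit of > 50000 nM in this assay, at which 4 of the 4 values shown sit.

The compounds shown leave open whether any aryl group on this aromatic nitrogen, or any change to the shared core, would bring a compound inside the measurable range.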